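Ester to nitrile on the thioether chain: compound 4

The compounds below may be only part of what the source reports. "The series", "measured", "known", "first", "only" and "open" are said of these compounds alone.

Measured so far in a functional assay on HCT-116 cells (Homo sapiens) for cytotoxicity, read by MTT assay, with a stated time of 48 h; a higher number here means a weaker inhibitor, a lower number a stronger inhibitor: compound 1 `O=C(CSCc1nc2cc([N+](=O)[O-])ccc2[nH]1)c1ccccc1` gives 12400 nM; compound 2 `O=C(CSCc1nc2cc([N+](=O)[O-])ccc2[nH]1)c1ccc(Br)cc1` gives 1780 nM. Compound 3 `CCOC(=O)CSCc1nc2cc([N+](=O)[O-])ccc2[nH]1` gives > 100000 nM, which is a limit of this assay and not a number.

Compound 3 therefore stands at the weak end of the three, at the limit of > 100000 nM in this assay, at which 1 of the 3 values shown sits. Compound 4 `N#CCSCc1nc2cc([N+](=O)[O-])ccc2[nH]1` differs from compound 3 by cyano in place of ethoxycarbonyl on a saturated chain carbon bound to a sulfur. Going by the values given here, no measured step alters this end of the chain; the steps that reach the same region are an at least 8.0-fold higher number from compound 1 to compound 3 (0.90 log units; beyond the scatter) and an at least 56-fold higher number from compound 2 to compound 3 (1.74 log units; beyond the scatter), both showing that giving up the aryl ketone for the ester weakens inhibition. Compound 4 also carries no aryl group, so its value is expected to stay near the limit, as a number no higher from compound 3 to compound 4 (the limit leaves the size open). For compound 4 the estimate is 100000 nM, within 30000 nM to 300000 nM.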

Compound 4, half-maximal inhibitory concentration: 28200 nM
For compound 4 the middle estimate is 3.5-fold (0.55 log units) above the measured one, outside the stated range (below it).
By their numbers in this assay, from the lowest: compound 2; then compound 1; then compound 4. At a limit, above all of these: compound 3.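

In this assay, the group on a saturated chain carbon bound to a sulfur changes the read-out even with no aryl ketone present: cyano in place of ethoxycarbonyl gives an at least 3.5-fold lower number from compound 3 to compound 4 (0.54 log units; beyond the scatter). Compound 4 carries no aryl group yet gives a measured number, so an aryl ketone is not required for a readable value in this series. Compound 3 stands at a limit of the assay, which leaves the full size of this step unknown: the limit of > 100000 nM in this assay, at which 1 of the 4 values shown sits.

From the compounds shown here alone, whether a carboxylic acid, a primary amide or a longer chain ending in nitrile at this place would give a lower or a higher number remains open.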